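Compound 1 to compound 4: one group exchanged

The source may report more compounds than this note shows. Statements on the series, on what has been measured and on what is new or still open speak of the compounds shown alone.

compound 1 `COc1cc(CNC(=O)CCCCCCC(C)C)ccc1OCCCCOc1ccc(C(N)=S)cc1`: 40700 nM
compound 2 `COc1cc(CNC(=O)CCCCCCC(C)C)ccc1OC(=O)c1ccc(C(N)=S)cc1`: > 50000 nM (a limit)
compound 3 `COc1cc(CNC(=O)CCCC/C=C/C(C)C)ccc1OCCCCOc1ccc(C(N)=S)cc1`: > 50000 nM (a limit)

Within the data shown here, in a functional assay on HeLa cells (Homo sapiens) for antiproliferative activity, read by MTT assay, with a stated time of 48 h (a lower number here means a stronger inhibitor, a higher number a weaker inhibitor), compound 1 gives 40700 nM, the only true number in this small set. The other two compounds reach only a limit, as shown by the limit of > 50000 nM in this assay, at which 2 of the 3 values shown sit. Compound 4 `COc1cc(CNC(=O)CCCCCCC(C)C)ccc1OCCCCOc1ccc(-c2cc(=S)ss2)cc1` differs from compound 1 by a group of 6 heavy atoms (3 carbon, 3 sulfur; one five-membered aromatic ring with 2 hetero atoms) in place of a group of 3 heavy atoms (1 carbon, 1 nitrogen, 1 sulfur; no ring), on an aromatic carbon. Among the measured compounds shown here, the one measured step, an at least 1.2-fold higher number from compound 1 to compound 3 (0.08 log units; that floor lies within the scatter), changes a chain and not an aromatic carbon, so it gives no size for this exchange. No step beyond the scatter is therefore expected in this assay, though a reading at the limit remains possible. For compound 4 the estimated value is 35000 nM, with an expected range of 15000 nM to 70000 nM. The expected change is a 1.2-fold lower number from compound 1 to compound 4 (0.07 log units; within the scatter).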

Compound 4, half-maximal inhibitory concentration: 44700 nM
Estimate against measurement, compound 4: 1.3-fold (0.11 log units) below; low and high end bracket the measured number.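

In this assay, the exchange on the aromatic carbon para to a large group gives a 1.1-fold higher number from compound 1 to compound 4 (0.04 log units; within the scatter). Among these compounds, this is the first reading at this position, and it does not separate the two groups, even though the five-membered aromatic ring enters and the hydrogen-bond donor of the leaving group is gone. On these data alone, whether an amine or a carboxylic acid on this carbon would give a step beyond the scatter stays open. The compounds shown also offer little room for reading weaker results: the limit of > 50000 nM in this assay, at which 2 of the 4 values shown sit.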